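Methyl on the Bridging Nitrogen: Working Notes

A few compounds are considered here, and "the series" means these few. Any claim that something is new, unique, unknown or untested is made for them only; others in the source may bear on it.

Measured so far in an assay on isolated protein for binding affinity to melatonin receptor type 1B (Homo sapiens); on this read-out higher numbers stand for weaker inhibition and lower numbers for stronger inhibition:
Compound 1, `COc1cccc(Nc2ccc(NC(=O)C(C)C)cc2)c1`, gives 84 nM.
Compound 2, `COc1cccc(N(C)c2ccc(NC(=O)C(C)C)cc2)c1`, gives 5.5 nM.
Compound 3, `CCCC(=O)Nc1ccc(Nc2cccc3c2CCO3)cc1`, gives 39 nM.

Compound 1 and compound 2 differ in one place: methyl in place of hydrogen on a nitrogen on an aromatic ring. Among the measured compounds shown here, that change gave a 15-fold lower number from compound 1 to compound 2 (1.18 log units; beyond the scatter), the only measured instance of this change in the set.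

Compound 3 carries a different core from compound 1; the difference between the two cores is not broken down here. On its own numbers compound 3 sits between the other two: its value lies below that of compound 1 and above that of compound 2, and both gaps are beyond the scatter.

Compound 4, `CCCC(=O)Nc1ccc(N(C)c2cccc3c2CCO3)cc1`, has not yet been measured. It differs from compound 3 by methyl in place of hydrogen on a nitrogen on an aromatic ring. For the measured compounds named here, this is the same change as from compound 1 to compound 2, made on the same kind of nitrogen with the same neighbours, so the one measured step is the only guide to what it does.

From compound 3 to compound 4 a step of about a 9.8-fold lower number from compound 3 to compound 4 (0.99 log units; beyond the scatter) is expected in this assay, resting on the size of a 15-fold lower number from compound 1 to compound 2 (1.18 log units; beyond the scatter) and tempered only by the fact that it rests on a single measured pair. The value expected for compound 4 is 4 nM, with a likely range from 1.5 nM to 12 nM.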

Compound 4, inhibition constant: 0.49 nM
Beside the measured number, compound 4's estimate is 8.2-fold (0.91 log units) above it; measured number below the stated range.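

In this assay, methyl in place of hydrogen on a nitrogen on an aromatic ring again gives a lower number, an 80-fold lower number from compound 3 to compound 4 (1.90 log units; beyond the scatter), so the direction of the change carries over to the second core. The size of the step does not carry over, and the gap between the two steps is larger than repeat measurements would explain: the same change on two cores in this assay, a 15-fold lower number (1.18 log units; beyond the scatter) from compound 1 to compound 2 and an 80-fold lower number (1.90 log units; beyond the scatter) from compound 3 to compound 4, 5.2-fold (0.72 log units) apart, beyond the scatter of two such steps With only two pairs, this shows that the change lowered the number on both cores shown and that a step measured on one core did not fix its size on the other; it does not show which difference between the cores goes with the larger step, or what size or direction the step would take on a third core.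

The compounds shown leave open whether ethyl or a longer chain on the same nitrogen would keep, extend or lose the lower number, as methyl is the only group other than hydrogen seen there. They also leave open whether the step keeps its direction when the amide chain gives way to a different group, such as a cyclopropyl amide or a carboxylic acid.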